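Ring-nitrogen substituent on the benzimidazole-free shared core: isopropyl

A few compounds are considered here, and "the series" means these few. Any claim that something is new, unique, unknown or untested is made for them only; others in the source may bear on it.

Hmm — avoid naming the core. Revised title below.

Ring-nitrogen substituent variation, compound 4

The series shares one core and differs only in the group on the aromatic nitrogen of the fused five-membered ring. Among the measured compounds shown here, compound 1 `CC(C)c1onc(-c2c(Cl)cccc2Cl)c1COc1ccc(-c2nc3ccc(C(=O)O)cc3n2CC(C)(C)C)cc1` carries neopentyl there and gives 13 nM in an assay on Huh-7 cells for agonist activity at Bile acid receptor (Homo sapiens), read by a luciferase reporter (a lower number here means that less compound is needed, a higher number that more compound is needed for the effect), the second highest of the three numbers measured so far. Compound 2 `CC(C)c1onc(-c2c(Cl)cccc2Cl)c1COc1ccc(-c2nc3ccc(C(=O)O)cc3n2C2CC2)cc1` carries cyclopropyl and gives 16.5 nM; the step is a 1.3-fold higher number from compound 1 to compound 2 (0.10 log units; within the scatter). Compound 3 `CC(C)c1onc(-c2c(Cl)cccc2Cl)c1COc1ccc(-c2nc3ccc(C(=O)O)cc3n2CC2CCCCC2)cc1` carries cyclohexylmethyl and gives 0.52 nM; here the step is a 25-fold lower number from compound 1 to compound 3 (1.40 log units; beyond the scatter), and from compound 2 it is a 32-fold lower number from compound 2 to compound 3 (1.50 log units; beyond the scatter).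

Compound 4 `CC(C)c1onc(-c2c(Cl)cccc2Cl)c1COc1ccc(-c2nc3ccc(C(=O)O)cc3n2C(C)C)cc1` is the next member. The change from compound 1 is isopropyl in place of neopentyl on an aromatic nitrogen. For the measured compounds named here, two measured steps bear on it. The exchange of neopentyl for cyclopropyl in compound 2 left the number where it was, and the only large movement came with the entry of cyclohexylmethyl in compound 3. The isopropyl group brings three carbon atoms in place of five, with no ring, and so resembles the neopentyl-to-cyclopropyl exchange rather than the step to compound 3. No step beyond the scatter is therefore expected in this assay for compound 4.

The estimate for compound 4 is 15 nM, ranging from 6 nM to 40 nM, which means an expected step of a 1.2-fold higher number from compound 1 to compound 4 (0.06 log units; within the scatter).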

Compound 4, half-maximal effective concentration: 3.39 nM
For compound 4 the middle estimate is 4.4-fold (0.65 log units) above the measured one; the whole stated range lies above it.
By their numbers in this assay, from the lowest: compound 3; then compound 4; then compounds 1 and 2 (each within the scatter of the next).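

Notes on the ring-nitrogen position: in this assay this position responds to more than the entry of cyclohexylmethyl, since isopropyl in place of neopentyl gives a 3.8-fold lower number from compound 1 to compound 4 (0.58 log units; beyond the scatter) and so separates two open-chain groups beyond the scatter. Isopropyl in place of cyclopropyl gives a 4.9-fold lower number from compound 2 to compound 4 (0.69 log units; beyond the scatter) as well, so compound 4 stands apart from compounds 1 and 2, which lie within the scatter of each other. Cyclohexylmethyl still keeps the lowest number, as the reverse exchange gives a 6.5-fold higher number from compound 3 to compound 4 (0.81 log units; beyond the scatter) and this shows that the numbers do not follow group size in one direction: the shorter isopropyl improves on neopentyl, while compound 3, with the larger cyclohexylmethyl, goes against any trend favouring smaller groups. Nothing measured here accounts for these differences. The compounds shown leave open whether a straight propyl chain or a cyclohexyl ring bound directly to the nitrogen would fall nearer compound 4 or compound 3. They also leave open how a chain ending in an amine or a carboxylic acid would behave at this position.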